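Closing the amine into an azetidine on the core

The source may hold more compounds than are shown below. What is called first, only, known or untested is meant among the compounds shown, and "the series" means these compounds.

Of the compounds shown here, three sharing one core have been measured in an assay on isolated protein for displacement of a labelled ligand from melanin-concentrating hormone receptor 1 (Homo sapiens); a lower number here means a stronger inhibitor, a higher number a weaker inhibitor. Compound 1 `CCCc1cc(NC2CCC2)c2cc(NC(=O)/C=C/c3ccc(C(F)(F)F)cc3)ccc2n1` gives 18 nM, compound 2 `CCCc1cc(N2CCCC2)c2cc(NC(=O)/C=C/c3ccc(C(F)(F)F)cc3)ccc2n1` gives 17 nM, and compound 3 `CCCc1cc(NC2CC2)c2cc(NC(=O)/C=C/c3ccc(C(F)(F)F)cc3)ccc2n1` gives 40 nM. Compound 3 thus has the highest number of the three; its nearest neighbour is compound 1, shown by a 2.2-fold higher number from compound 1 to compound 3 (0.35 log units; beyond the scatter), and its furthest is compound 2, shown by a 2.4-fold higher number from compound 2 to compound 3 (0.37 log units; beyond the scatter).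

Compound 4 `CCCc1cc(N2CCC2)c2cc(NC(=O)/C=C/c3ccc(C(F)(F)F)cc3)ccc2n1` is not yet measured. It differs from compound 3 in one place: azetidin-1-yl in place of cyclopropylamino on an aromatic carbon. The step that bears most directly on it is the corresponding ring closure one ring size up, a 1.1-fold lower number from compound 1 to compound 2 (0.02 log units; within the scatter), which stayed within the scatter. Among the measured compounds shown here, the two steps reaching compound 3 show only that the smaller ring costs a modest amount against the larger one, and do not speak to closing the amine itself. He therefore expects compound 4 to show no step beyond the scatter, a 1.1-fold lower number from compound 3 to compound 4 (0.06 log units; within the scatter), and estimates for compound 4 a value of 35 nM, within a range from 15 nM to 80 nM.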

Compound 4, half-maximal inhibitory concentration: 2.8 nM
For compound 4 the middle estimate is 13-fold (1.10 log units) above the measured one; the whole stated range lies above it.
By their numbers in this assay, from the lowest: compound 4; then compounds 2 and 1 (each within the scatter of the next); then compound 3.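

Closing the amine on this aromatic carbon has no single effect: the same atoms joined differently give a 14-fold lower number from compound 3 to compound 4 (1.15 log units; beyond the scatter), whereas the closure one ring size up gave a 1.1-fold lower number from compound 1 to compound 2 (0.02 log units; within the scatter). The azetidin-1-yl group also stands apart from the larger pyrrolidin-1-yl and the open cyclobutylamino groups, with a 6.1-fold lower number from compound 2 to compound 4 (0.78 log units; beyond the scatter) and a 6.4-fold lower number from compound 1 to compound 4 (0.81 log units; beyond the scatter), so compound 4 is the most potent of the four in this assay, and the gain belongs to this particular ring rather than to ring closure as such. Nothing measured here explains why this ring stands apart.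

The compounds shown leave open whether piperidin-1-yl or an open dimethylamino group would fall in line with pyrrolidin-1-yl or with azetidin-1-yl. They also leave open whether a fluorine or a hydroxyl group on the azetidine ring would keep the low number, and whether it would survive replacing the propyl group with a longer chain.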